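The compounds below may be only part of what the source reports. "The series", "measured", "known", "first", "only" and "open" are said of these compounds alone.

Working notes on the thiosemicarbazone series.

The shared core carries a substituted aromatic ring at one end. Compound 1 `Cc1ccc(/C=N/NC(=S)N2CCNCC2)cc1` gives 70000 nM in a functional assay on HL-60 cells (Homo sapiens) for antiproliferative activity, with a stated time of 48 h; a lower number here means a stronger inhibitor, a higher number a weaker inhibitor. Compound 2 `S=C(N/N=C/c1ccccc1)N1CCNCC1`, the unsubstituted analogue, gives 63000 nM in this assay. Going by the values given here, the only step measured so far, a 1.1-fold lower number from compound 1 to compound 2 (0.05 log units; within the scatter), is within the scatter, so the methyl on the aromatic carbon has no visible effect on the numbers at hand.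

Compound 3 `COc1ccc(/C=N/NC(=S)N2CCNCC2)cc1` carries a methoxy on the aromatic ring. For compound 3 the entry in this assay is "not determined" (no result reported), so no result is available and it cannot be placed against compound 1 or compound 2 on the numbers shown.

Compound 4 `S=C(N/N=C/c1ccc(Cl)cc1)N1CCNCC1` differs from compound 3 by one change: chloro in place of methoxy on an aromatic carbon, placed on an aromatic carbon of a six-membered aromatic ring of carbon only, para to a large group. Among the compounds with values here, no measured step covers this exchange. Within the data shown here, the one step on record, from compound 1 to compound 2, concerns a methyl and is within the scatter; it gives no hint that a small group on that aromatic carbon shifts this assay beyond the scatter. The expectation for compound 4 in this assay is therefore a number in the same region as compound 1 and compound 2, with no direction favoured beyond the scatter. Compound 4 is estimated at 60000 nM, within 20000 nM to 180000 nM.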

Compound 4, half-maximal inhibitory concentration: 69000 nM
Estimate against measurement, compound 4: 1.2-fold (0.06 log units) below, within the range that was stated.
By their numbers in this assay, from the lowest: compounds 2, 4 and 1 (each within the scatter of the next).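

In this assay the step with chloro in place of hydrogen on an aromatic carbon reads a 1.1-fold higher number from compound 2 to compound 4 (0.04 log units; within the scatter) and the step with chloro in place of methyl reads a 1.0-fold lower number from compound 1 to compound 4 (0.01 log units; within the scatter), and both lie within the scatter. The earlier compounds shown here compared only methyl with hydrogen, whereas this aromatic carbon, para to a large group, now carries three different occupants, a halogen among them, and none of the three steps separates one from another in this assay. No supporting measurement is available that could explain this flat result.

The steps that involve compound 3 cannot be read, so the methoxy remains unplaced against hydrogen, methyl and chloro. Going by these compounds, it also remains open whether an amine, a carboxylic acid or a longer chain on this aromatic carbon would move the number beyond the scatter, and whether a change elsewhere on the shared core would do so.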